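Trifluoromethyl for Methyl on a Hydroxamic Acid Series

The source may report more compounds than this note shows. Statements on the series, on what has been measured and on what is new or still open speak of the compounds shown alone.

The measured compounds:
Compound 1, `COc1cc2c(Oc3ccc(NC(=O)c4nn(-c5ccccc5)ccc4=O)cc3)ccnc2cc1OCCCC(=O)NO`, gives 7410 nM.
Compound 2, `COc1cc2c(Oc3ccc(NC(=O)c4nn(-c5cccc(C)c5)cc(C)c4=O)cc3)ccnc2cc1OCCCCCCC(=O)NO`, gives 1680 nM.
Compound 3, `COc1cc2c(Oc3ccc(NC(=O)c4nn(-c5ccccc5F)cc(C)c4=O)cc3F)ccnc2cc1OCCCC(=O)NO`, gives 2100 nM.

In a functional assay on MCF7 cells (Homo sapiens) for inhibition, read by MTT assay, with a stated time of 72 h (a lower number here means a stronger inhibitor, a higher number a weaker inhibitor), compound 2 carries the smallest number of the three. Compound 3 stands so close that the two cannot be told apart within the usual scatter, while compound 1 sits beyond the scatter at a higher number. No two of these compounds differ in a single place, so none of the gaps between them can be tied to one structural change.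

Compound 4, `COc1cc2c(Oc3ccc(NC(=O)c4nn(-c5cccc(C(F)(F)F)c5)cc(C)c4=O)cc3)ccnc2cc1OCCCCCCC(=O)NO`, is set against compound 2 by a single change: trifluoromethyl in place of methyl on an aromatic carbon. Among the measured compounds shown here, nothing among the measured compounds isolates this exchange, so there is no measured step to lean on. The expectation is therefore that the step of a 1.1-fold lower number from compound 2 to compound 4 (0.05 log units; within the scatter) stays within the usual scatter, in no firm direction. Compound 4 is estimated at 1500 nM, with a likely range from 500 nM to 4500 nM.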

Compound 4, half-maximal inhibitory concentration: 750 nM
Compound 4: the middle estimate sits 2.0-fold (0.30 log units) above what was measured; the measured number falls inside the stated range.
By their numbers in this assay, from the lowest: compound 4; then compounds 2 and 3 (each within the scatter of the next); then compound 1.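

In this assay, among the compounds shown here, replacing 3-methylphenyl with 3-(trifluoromethyl)phenyl gives a 2.2-fold lower number from compound 2 to compound 4 (0.35 log units; beyond the scatter), the first reading of this exchange and a modest one. It shows that this aromatic carbon, meta to a large group, is not indifferent to what it carries, and that trifluoromethyl, with its three fluorine atoms, is accepted there and goes with the lower number. The evidence at hand does not speak to the reason for this step.

The compounds shown leave open how a chlorine atom, a nitrile or a methoxy group would read on this same carbon. They also leave open whether the step would hold on the shorter chain carried by compound 1, since this single pair shares the longer chain.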